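The source may hold more compounds than are shown below. What is called first, only, known or untested is meant among the compounds shown, and "the series" means these compounds.

Measured compounds:
compound 1 `Cc1ccc(C(=O)OC2(C(=O)Nc3ccc([N+](=O)[O-])cc3)CCCCC2)cc1` — 32 nM
compound 2 `O=C(OC1(C(=O)Nc2ccc([N+](=O)[O-])cc2)CCCCC1)c1ccc(Br)cc1` — 523 nM
compound 3 `O=C(OC1(C(=O)Nc2ccc([N+](=O)[O-])cc2)CCCCC1)c1ccccc1I` — 396 nM

In an ADME assay on WI-38 cells (Homo sapiens) for inhibition, read by MTT assay, with a stated time of 72 h (on this read-out higher numbers stand for weaker inhibition and lower numbers for stronger inhibition), compound 3 stands second highest of the three numbers; one of its neighbouring steps lies within the scatter (a 1.3-fold lower number from compound 2 to compound 3 (0.12 log units; within the scatter)) and the other beyond it (a 12-fold higher number from compound 1 to compound 3 (1.09 log units; beyond the scatter)). Compound 4 `O=C(OC1(C(=O)Nc2ccc([N+](=O)[O-])cc2)CCCCC1)c1ccccc1` differs from compound 3 by hydrogen in place of iodo on an aromatic carbon. Among the measured compounds shown here, no measured step removes a halogen to leave a bare phenyl, so the closest guides are a 16-fold higher number from compound 1 to compound 2 (1.21 log units; beyond the scatter) and a 12-fold higher number from compound 1 to compound 3 (1.09 log units; beyond the scatter), both large, which show that substituents on this ring can move the numbers strongly in this assay. Removing the iodo gives a ring unlike any measured one, so compound 4 is expected to fall somewhere between the halogen-bearing and methyl-bearing analogues, with a step estimated as a 2.0-fold lower number from compound 3 to compound 4 (0.30 log units; within the scatter). For compound 4 the estimate is 200 nM, range 40 nM to 1000 nM.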

Compound 4, half-maximal inhibitory concentration: 246 nM
Beside the measured number, compound 4's estimate is 1.2-fold (0.09 log units) below it; low and high end bracket the measured number.
By their numbers in this assay, from the lowest: compound 1; then compounds 4, 3 and 2 (each within the scatter of the next, the first and the last beyond it).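

In this assay, taking the iodo off the ring leaves the number within the scatter (a 1.6-fold lower number from compound 3 to compound 4 (0.21 log units; within the scatter)), whereas taking the bromo off gives a modest step (a 2.1-fold lower number from compound 2 to compound 4 (0.33 log units; beyond the scatter)). The bare phenyl ring still stands apart from the methyl-bearing ring (a 7.7-fold higher number from compound 1 to compound 4 (0.89 log units; beyond the scatter)), so the low number of compound 1 goes with the methyl group and not merely with the absence of a halogen. Nothing given here explains these steps. On these data alone, whether an ethyl, a methoxy or an amine on this ring would track methyl or the halogens stays open, as does whether methyl behaves the same elsewhere on the ring.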